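The source may hold more compounds than are shown below. What is called first, only, known or untested is meant among the compounds shown, and "the series" means these compounds.

Compound 1 `O=S(=O)(/C=C/c1ccc(Cl)cc1Cl)Cc1ccc(Nc2ncnc3ccccc23)cc1` and compound 2 `O=S(=O)(/C=C/c1ccc(Cl)c(Cl)c1)Cc1ccc(Nc2ncnc3ccc(Br)cc23)cc1` are close in a functional assay on HT-29 cells (Homo sapiens); a lower number here means a stronger inhibitor of growth, a higher number a weaker inhibitor of growth: compound 1 gives 24000 nM, and compound 2 gives 27000 nM. Compound 3 `O=S(=O)(/C=C/c1ccc(Cl)cc1)Cc1ccc(Nc2ncnc3ccc(Br)cc23)cc1` reaches only the limit of > 100000 nM in this assay; that value is a limit rather than a number (the limit of > 100000 nM in this assay, at which 1 of the 3 values shown sits). From compound 3 to compound 2 the change is chloro in place of hydrogen on an aromatic carbon, and it yields an at least 3.7-fold lower number from compound 3 to compound 2 (0.56 log units; beyond the scatter). Compound 4 `O=S(=O)(/C=C/c1ccc(Cl)cc1Cl)Cc1ccc(Nc2ncnc3cc(Cl)ccc23)cc1` comes from compound 1 by chloro in place of hydrogen on an aromatic carbon, the same kind of change, though the place differs: here it is part of a fused system of two rings, meta and para to a fused ring, rather than ortho to a chloro group and meta to a large group. The difference between the cores of compound 1 and compound 3 is not broken down here. Compound 4 is expected to give 20000 nM, between 8000 nM and 60000 nM, a step of a 1.2-fold lower number from compound 1 to compound 4 (0.08 log units; within the scatter) that is expected to stay modest.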

Compound 4, concentration for 50% growth inhibition: 59000 nM
The estimate for compound 4 lay 3.0-fold (0.47 log units) below the measured number, and the stated range covers the measured number.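

In this assay, chloro in place of hydrogen on an aromatic carbon gives a 2.5-fold higher number from compound 1 to compound 4 (0.39 log units; beyond the scatter). Set beside the earlier step, this change does not carry over from one core to the other: the same change on two cores in this assay, an at least 3.7-fold lower number (0.56 log units; beyond the scatter) from compound 3 to compound 2 and a 2.5-fold higher number (0.39 log units; beyond the scatter) from compound 1 to compound 4, at least 9.1-fold (0.95 log units) apart, beyond the scatter of two such steps. What this does not show is whether the core or the place of the chloro decides the outcome, as the two vary together in these pairs, with the chloro of compound 4 on the fused system of two rings.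

Still open, going by these compounds, is how compound 4 would compare with an analogue carrying a methoxy group or an amine in the place of its chloro. Also open, on these data alone, is whether the same chloro on the core of compound 2 would follow compound 4.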